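A Five-Membered Ring Replaces an Open Side Chain

The source may report more compounds than this note shows. Statements on the series, on what has been measured and on what is new or still open speak of the compounds shown alone.

Of the compounds shown here, three have been measured so far in a toxicity assay on MRC5 cells (Homo sapiens) for cytotoxicity, read by MTT assay, with a stated time of 72 h; on this read-out lower numbers stand for stronger inhibition and higher numbers for weaker inhibition. Compound 1 `CN1CCCCC1CCO/N=C1C(=C2/C(=O)Nc3ccccc32)/Cc2ccccc2/1` gives > 2000 nM, which is a limit of the assay and not a number. Compound 2 `CN1CCCCC1CCO/N=C1C(=C2/C(=O)Nc3ccc(F)cc32)/Nc2ccccc2/1` gives > 2000 nM, again a limit. Compound 3 `CN(C)CCCO/N=C1C(=C2/C(=O)Nc3ccccc32)/Nc2ccccc2/1` gives > 2000 nM, also a limit. The three therefore share one position, (the limit of > 2000 nM in this assay, at which 3 of the 3 values shown sit), and cannot be ranked against each other.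

Compound 4 `CN1CCCC1CCO/N=C1C(=C2/C(=O)Nc3ccccc32)/Nc2ccccc2/1` differs from compound 3 in one place: 1-methylpyrrolidin-2-yl in place of (dimethylamino)methyl on a saturated chain carbon, two bonds along the chain from an oxygen on an unsaturated carbon. In words, this puts 1-methylpyrrolidin-2-yl in place of (dimethylamino)methyl on a saturated chain carbon, two bonds along the chain from an oxygen on an unsaturated carbon.

For the measured compounds named here, no pair of measured compounds differs in only one place, so no measured step serves as a guide. No shift beyond the usual scatter is expected, in either direction. The expected change is a step that the limit leaves unreadable from compound 3 to compound 4. This expectation starts from compound 3 at > 2000 nM, a limit. For compound 4 the estimate is 3000 nM, with an expected range of 1500 nM to 6000 nM.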

Compound 4, half-maximal inhibitory concentration: > 2000 nM
Compound 4: only a limit was reported; the forecaster's own chance of this, stated with the estimate: 80%; the middle value is on the limit's open side.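

Compound 4 gives > 2000 nM, which is a limit of the assay and not a number. For the compounds shown here, compound 3 also stands at a limit, so no step from compound 3 to compound 4 can be read. The compounds shown leave open how far each lies beyond that limit, and so whether any structural change alters the value: the limit of > 2000 nM in this assay, at which 4 of the 4 values shown sit.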